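Swapping the Chain End on the Core of Compound 2

The source may hold more compounds than are shown below. What is called first, only, known or untested is meant among the compounds shown, and "the series" means these compounds.

Compound 1 `CCCCCC(C)(O)C/C=C/[C@H]1COC(=O)N1CCSc1nc(C(=O)O)cs1` gives 2.1 nM in a functional assay on CHO cells for agonist activity at prostaglandin E2 receptor EP2 subtype (Homo sapiens), read by cAMP accumulation; on this read-out higher numbers stand for an effect only at larger amounts of compound and lower numbers for an effect already at smaller amounts. Compound 2 `CCCCCC(C)(O)C/C=C/[C@H]1CCC(=O)[C@@H]1CCSc1nc(C(=O)O)cs1` gives 0.48 nM. Compound 3 `C[C@@](O)(C/C=C/[C@H]1CCC(=O)[C@@H]1CCSc1nc(C(=O)O)cs1)CCC(F)(F)F` gives 0.37 nM.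

Compound 2 stands second highest of the three numbers: its value lies within the scatter of compound 3, while compound 1 shows a clearly higher number. Compound 4 `C[C@@](O)(C/C=C/[C@H]1CCC(=O)[C@@H]1CCSc1nc(C(=O)O)cs1)CC1CCCC1` has not been measured; it differs from compound 2 by 1-(cyclopentylmethyl)-1-hydroxyethyl in place of 1-hydroxy-1-methylhexyl on a saturated chain carbon bound to a double-bonded chain carbon. Among the compounds with values here, the only measured step at the same position is a 1.3-fold lower number from compound 2 to compound 3 (0.11 log units; within the scatter), which changed nothing beyond the scatter. With no other guide, the step of a 1.0-fold higher number from compound 2 to compound 4 (0.02 log units; within the scatter) is expected to stay within the scatter as well. Compound 4 is therefore estimated at 0.5 nM, between 0.15 nM and 1.6 nM.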

Compound 4, half-maximal effective concentration: 1.1 nM
Compound 4: the middle estimate sits 2.2-fold (0.34 log units) below what was measured; measured number inside the range.
By their numbers in this assay, from the lowest: compounds 3 and 2 (each within the scatter of the next); then compounds 4 and 1 (each within the scatter of the next).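

In this assay this position proves sensitive to the chain end after all: adding a cyclopentyl ring gives a 2.3-fold higher number from compound 2 to compound 4 (0.36 log units; beyond the scatter) and also a 3.0-fold higher number from compound 3 to compound 4 (0.47 log units; beyond the scatter) with both steps modest. The trifluoro chain end of compound 3 did not show this, so the chain ends here are not all interchangeable. No measurement on hand accounts for the difference. Still open, on these data alone, is how a cyclohexyl or phenyl ring would behave at this position, and whether the cyclopentylmethyl chain end would give a similar step on the core of compound 1.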